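Fluorine on the Aryl Ether Ring of Isoxazole Piperazines

This account rests on a few compounds, and the source may have more. Where it says the series, first, only, none or still open, it means among the compounds named here.

Measured compounds:
compound 1, `FC(F)(F)c1ccc(CN2CCN(Cc3cc(-c4ccc(OCc5ccccc5)cc4)on3)CC2)cc1`, 2900 nM in a functional assay on MCF7 cells (Homo sapiens) for antiproliferative activity, read by sulforhodamine B assay, with a stated time of 72 h; a lower number here means a stronger inhibitor, a higher number a weaker inhibitor
compound 2, `Fc1ccccc1COc1ccc(-c2cc(CN3CCN(Cc4ccc(C(F)(F)F)cc4)CC3)no2)cc1`, 3000 nM in this assay
compound 3, `N#Cc1cccc(COc2ccc(-c3cc(CNC4CCN(Cc5ccccc5)CC4)no3)cc2)c1`, 2500 nM in this assay

Compound 1 carries a benzyloxy group on the aryl ring attached to the isoxazole, and compound 2 differs from it by a single change: fluoro in place of hydrogen on an aromatic carbon. In this assay this gave a 1.0-fold higher number from compound 1 to compound 2 (0.01 log units; within the scatter), so the two compounds sit within the scatter of each other and no order between them is claimed. Compound 3 belongs to the same family but its core is not the same as that of compound 1; the difference between the two cores is not broken down here. In this assay compound 3 gives 2500 nM, which lies within the scatter of both compound 1 and compound 2.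

Compound 4, `N#Cc1cccc(COc2ccc(-c3cc(CNC4CCN(Cc5ccccc5)CC4)no3)cc2F)c1`, has not yet been measured. It differs from compound 3 by fluoro in place of hydrogen on an aromatic carbon. This is the same kind of change as that from compound 1 to compound 2, though the surroundings differ: in the earlier pair the fluoro sits ortho to a large group, whereas here it sits ortho to a (3-cyanobenzyl)oxy group and meta to a large group. Because the earlier step of a 1.0-fold higher number from compound 1 to compound 2 (0.01 log units; within the scatter) stayed within the scatter, a similarly small step is expected here, and the estimated step from compound 3 to compound 4 in this assay is no change at the digits printed from compound 3 to compound 4 (within the scatter). Compound 4 is therefore expected to give about 2500 nM, within a range of 1100 nM to 5500 nM, in this assay.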

Compound 4, half-maximal inhibitory concentration: 2700 nM
Estimate against measurement, compound 4: 1.1-fold (0.03 log units) below; the range from low to high includes it.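

In this assay, putting fluoro in place of hydrogen on an aromatic carbon, ortho to a (3-cyanobenzyl)oxy group, gave a 1.1-fold higher number from compound 3 to compound 4 (0.03 log units; within the scatter). Set beside the earlier step, the change reads alike on the two cores, and the gap between the two steps gives no ground for treating them as different: the same change on two cores in this assay, a 1.0-fold higher number (0.01 log units; within the scatter) from compound 1 to compound 2 and a 1.1-fold higher number (0.03 log units; within the scatter) from compound 3 to compound 4, 1.0-fold (0.02 log units) apart, within the scatter of two such steps. This shows that in these two pairs the change left the number within the scatter on either core, but it does not show that fluoro would do the same on other cores or at other places on the ring, and two pairs support no general rule for the series.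

The compounds shown leave open what a chloro, a methoxy or a hydroxyl group would do on the same aromatic carbon ortho to the (3-cyanobenzyl)oxy group, where only hydrogen and fluoro appear here. They also leave open whether a carboxylic acid or an amide in place of the nitrile, or a longer chain in place of the benzyl ether link, would move the number in this assay beyond the scatter.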